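Benzyl in place of pyridin-4-yl on the sulfur

The source may report more compounds than this note shows. Statements on the series, on what has been measured and on what is new or still open speak of the compounds shown alone.

Measured in a functional assay (microsomes, liver) with Rattus norvegicus as the target; on this read-out lower numbers stand for stronger inhibition and higher numbers for weaker inhibition:
Compound 1 `Cc1c(C)c2c(c(C)c1N)CC(C)(CSc1ccc(F)cc1)O2`: 220 nM
Compound 2 `Cc1c(C)c2c(c(C)c1N)CC(C)(CSc1ccc(O)cc1)O2`: 220 nM
Compound 3 `Cc1c(C)c2c(c(C)c1N)CC(C)(CSc1ccncc1)O2`: 630 nM

Compound 3 has the highest number of the three. The steps leading to it lie beyond the scatter, a 2.9-fold higher number from compound 1 to compound 3 (0.46 log units; beyond the scatter) and a 2.9-fold higher number from compound 2 to compound 3 (0.46 log units; beyond the scatter), while no change at the digits printed from compound 1 to compound 2 (within the scatter) separates nothing. Compound 4 `Cc1c(C)c2c(c(C)c1N)CC(C)(CSCc1ccccc1)O2` carries one change: benzyl in place of pyridin-4-yl on a sulfur. Among the compounds with values here, no measured step involves benzyl, so the evidence is indirect. Benzyl has an aromatic ring of carbon only, as do the aryl groups of compound 1 and compound 2, so the reverse of a 2.9-fold higher number from compound 1 to compound 3 (0.46 log units; beyond the scatter) offers the nearest guide. A modest fall is therefore expected in this assay, and the expected change is a 2.0-fold lower number from compound 3 to compound 4 (0.29 log units; within the scatter). The estimate for compound 4 is 320 nM, within an expected range of 130 nM to 750 nM.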

Compound 4, half-maximal inhibitory concentration: 260 nM
Beside the measured number, compound 4's estimate is 1.2-fold (0.09 log units) above it; the measured number falls inside the stated range.
By their numbers in this assay, from the lowest: compounds 1, 2 and 4 (each within the scatter of the next); then compound 3.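

With benzyl on the sulfur, this assay shows a 2.4-fold lower number from compound 3 to compound 4 (0.38 log units; beyond the scatter) and so separates compound 4 from the pyridin-4-yl compound. Benzyl also stands level with both aryl groups, with a 1.2-fold higher number from compound 1 to compound 4 (0.07 log units; within the scatter) and a 1.2-fold higher number from compound 2 to compound 4 (0.07 log units; within the scatter) both within the scatter, so the three compounds with a ring of carbon only form one group, and compound 3, with its ring nitrogen, goes against it. No measurement shown here gives a reason for these steps.

Going by these compounds, whether a longer chain such as phenethyl on the sulfur would give a similar number remains open. So does the effect of an amine or a carboxylic acid on the benzyl ring, or of a saturated cyclohexyl ring in its place.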